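The compounds below may be only part of what the source reports. "The series", "measured", "known", "first", "only" and "open" are said of these compounds alone.

Working notes on the series. Within the data shown here, in a functional assay on DU-145 cells (Homo sapiens) for inhibition, read by trypan blue exclusion, with a stated time of 96 h (a higher number here means a weaker inhibitor of growth, a lower number a stronger inhibitor of growth), compound 1 `Cc1ccc(/C=C(\C(=O)c2ccc([N+](=O)[O-])cc2)S(=O)(=O)Cc2ccc(Cl)cc2)s1` gives 25000 nM, the higher of the two numbers so far. Among the measured compounds shown here, the only other measured member, compound 2 `Cc1ccc(CS(=O)(=O)/C(=C/c2cc(C)cc(C)c2)C(=O)c2ccc(Cl)cc2)cc1`, gives 10000 nM, and the gap between the two lies beyond the scatter. Next in line is compound 3 `Cc1ccsc1/C=C(\C(=O)c1ccc([N+](=O)[O-])cc1)S(=O)(=O)Cc1ccc(Cl)cc1`, which has the same atoms as compound 1, joined differently: 3-methylthiophen-2-yl in place of 5-methylthiophen-2-yl on a double-bonded chain carbon bound to a double-bonded chain carbon. In words, 3-methylthiophen-2-yl stands in place of 5-methylthiophen-2-yl on a double-bonded chain carbon bound to a double-bonded chain carbon. For the measured compounds named here, no measured pair shows this change, so the data offer no direct guide to its size. In this assay, going by these compounds, no step beyond the scatter is expected, and the direction stays open, with the expected step being a 1.3-fold lower number from compound 1 to compound 3 (0.10 log units; within the scatter). For compound 3 the estimate is 20000 nM, with an expected range from 8000 nM to 50000 nM.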

Compound 3, concentration for 50% growth inhibition: 1000 nM
Compound 3: middle estimate off by 20-fold (1.30 log units), on the high side; the measured number lies below the stated range.
By their numbers in this assay, from the lowest: compound 3; then compound 2; then compound 1.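

In this assay, a change that only moves the methyl group, with 3-methylthiophen-2-yl in place of 5-methylthiophen-2-yl, gives a 25-fold lower number from compound 1 to compound 3 (1.40 log units; beyond the scatter). Among these compounds, this is the first pair that differs in one place, and it shows that the number responds strongly to this change on a double-bonded chain carbon bound to a double-bonded chain carbon, even with the same atoms. Nothing at hand accounts for the size of this step.

The pair cannot separate a gain from the methyl group in 3-methylthiophen-2-yl from a loss caused by the methyl group in 5-methylthiophen-2-yl; unsubstituted thiophen-2-yl on the same core would be the missing reference. Going by these compounds, how 3-ethylthiophen-2-yl or 3-methoxythiophen-2-yl would compare at this place also remains open.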